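The source may hold more compounds than are shown below. What is called first, only, known or untested is meant among the compounds shown, and "the series" means these compounds.

Measured so far in an assay on isolated protein for displacement of a labelled ligand from Adrenergic receptor alpha-1 (Rattus norvegicus); a higher number here means a weaker inhibitor, a lower number a stronger inhibitor:
- compound 1 `CCNC(=O)C1CCN(c2nc(N)c3cc(OC)c(OC)cc3n2)CC1`: 1.64 nM
- compound 2 `COc1cc2nc(N3CCC(C(=O)NC4CCCC4)CC3)nc(N)c2cc1OC`: 0.63 nM

Compound 2 holds the lowest of the two numbers; its nearest neighbour is compound 1, separated by the step of a 2.6-fold lower number from compound 1 to compound 2 (0.42 log units; beyond the scatter). Compound 3 `COc1cc2nc(N3CCC(C(=O)NCCO)CC3)nc(N)c2cc1OC` differs from compound 2 by 2-hydroxyethyl in place of cyclopentyl on an amide-type nitrogen. For the measured compounds named here, the only measured step that bears on this position is a 2.6-fold lower number from compound 1 to compound 2 (0.42 log units; beyond the scatter), where a small chain gave way to the carbocycle; the present change goes the other way, back to a short chain, now carrying a hydroxyl, for which no step is measured. A modest rise in this assay is therefore expected, a 2.5-fold higher number from compound 2 to compound 3 (0.40 log units; beyond the scatter). Compound 3 is estimated at 1.6 nM, range 0.6 nM to 4.5 nM.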

Compound 3, inhibition constant: 1.73 nM
Beside the measured number, compound 3's estimate is 1.1-fold (0.03 log units) below it; low and high end bracket the measured number.
By their numbers in this assay, from the lowest: compound 2; then compounds 1 and 3 (each within the scatter of the next).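

In this assay, the step of a 2.7-fold higher number from compound 2 to compound 3 (0.44 log units; beyond the scatter) shows that 2-hydroxyethyl on the amide-type nitrogen does not hold the level seen with cyclopentyl. The hydroxy in place of hydrogen on the saturated chain carbon gives a 1.1-fold higher number from compound 1 to compound 3 (0.02 log units; within the scatter) and so does not separate 2-hydroxyethyl from ethyl at this position. Nothing available explains either step.

Still open, on these data alone, is whether the lower number of compound 2 depends on the ring itself or on the carbon count of the group. An open n-pentyl chain, a cyclohexyl ring or a 2-aminoethyl group would extend the comparison.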